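Cyclopropylmethyl for Methyl on the Amide Nitrogen

The source may report more compounds than this note shows. Statements on the series, on what has been measured and on what is new or still open speak of the compounds shown alone.

Among the measured compounds shown here, compound 3 `CN(C(=O)c1ccccc1OCc1ccccc1)[C@@H]1CCC[C@H](N)C1` gives 3670 nM in an assay on HEK293 cells for inhibition of transient receptor potential cation channel subfamily M member 8 (Homo sapiens), read by FLIPR and calcium flux (a higher number here means a weaker inhibitor, a lower number a stronger inhibitor), the higher of the two numbers known, though within the scatter of compound 1 `CCN(C(=O)c1ccccc1OCc1ccccc1)[C@@H]1CC[C@@H](N)C1`, which gives 2600 nM. For compound 2 `CN(C(=O)c1ccccc1OCc1ccccc1)[C@@H]1CCNC1` this assay reports only a limit, > 10000 nM (the limit of > 10000 nM in this assay, at which 1 of the 3 values shown sits). For the measured compounds named here, the one measured step, an at least 2.7-fold lower number from compound 2 to compound 3 (0.43 log units; beyond the scatter), concerns the ring and not the substituent on the amide-type nitrogen. Compound 4 `N[C@H]1CCC[C@@H](N(CC2CC2)C(=O)c2ccccc2OCc2ccccc2)C1` differs from compound 3 by cyclopropyl in place of hydrogen on a saturated chain carbon bound to an amide-type nitrogen; cut one bond further out, methyl becomes cyclopropylmethyl. Going by the values given here, no measured step covers this change; compound 1 and compound 3, which differ both at the amide-type nitrogen substituent and in the ring, sit within the scatter of each other. A step of a 1.5-fold lower number from compound 3 to compound 4 (0.17 log units; within the scatter) is therefore expected, none beyond the scatter. Compound 4 is estimated at 2500 nM, from 900 nM to 7000 nM.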

Compound 4, antagonist equilibrium constant: 665 nM
For compound 4 the middle estimate is 3.8-fold (0.58 log units) above the measured one, and the stated range ends above it.
By their numbers in this assay, from the lowest: compound 4; then compounds 1 and 3 (each within the scatter of the next). At a limit, above all of these: compound 2.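

The substituent on the amide-type nitrogen turns out to be a place that can move the number in this assay: methyl to cyclopropylmethyl gives a 5.5-fold lower number from compound 3 to compound 4 (0.74 log units; beyond the scatter). Among the compounds shown here, the earlier measured step concerned only the ring, so this is the first reading at this nitrogen. Nothing shown accounts for the size of this step.

Still open, from the compounds shown here alone, is whether the three-membered ring itself matters or only the length of the substituent. A propyl chain or a cyclobutylmethyl group on the core of compound 3 would separate the two.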